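The compounds below may be only part of what the source reports. "The series", "measured", "known", "first", "only" and "open" are said of these compounds alone.

Three compounds measured in a functional assay on MCF7 cells (Homo sapiens) for cytotoxicity, read by MTT assay, with a stated time of 72 h (on this read-out lower numbers stand for stronger inhibition and higher numbers for weaker inhibition), set the scene. Compound 1 `Cc1cc(=O)n(-c2ccccc2C(F)(F)F)nc1C(=O)Nc1ccc(Oc2ncnc3ccsc23)c(F)c1` gives 6020 nM in this assay. Compound 2 `Cc1cc(=O)n(-c2ccccc2OC(F)(F)F)nc1C(=O)Nc1ccc(Oc2ncnc3sccc23)cc1` gives 11000 nM in this assay. Compound 3 `O=C(Nc1ccc(Oc2ncnc3ccsc23)c(F)c1)c1nn(-c2ccc(F)cc2)ccc1=O` gives 5720 nM in this assay, the lowest of the three numbers, yet its gaps to compound 1 and to compound 2 both fall inside the usual scatter of repeated measurements, so the three are best taken as sitting together rather than in any order.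

Compound 4 `Cc1ccc(-n2ccc(=O)c(C(=O)Nc3ccc(Oc4ncnc5ccsc45)c(F)c3)n2)cc1` has not yet been measured. It differs from compound 3 in a single spot: methyl in place of fluoro on an aromatic carbon, a swap that leaves the rest of the molecule untouched. Within the data shown here, no pair of measured compounds shows this exact swap, so there is nothing here to say which way it should move the number. With the three measured values so close together, the expectation for this assay is a step no larger than the scatter, in no particular direction, which as a 1.0-fold lower number from compound 3 to compound 4 (0.02 log units; within the scatter) is the estimate meant here. Compound 4 is therefore expected to give about 5500 nM in this assay, somewhere between 2500 nM and 12000 nM.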

Compound 4, half-maximal inhibitory concentration: 23200 nM
For compound 4 the middle estimate is 4.2-fold (0.63 log units) below the measured one; the whole stated range lies below it.
By their numbers in this assay, from the lowest: compounds 3, 1 and 2 (each within the scatter of the next); then compound 4.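

In this assay, changing 4-fluorophenyl to 4-methylphenyl gives a 4.1-fold higher number from compound 3 to compound 4 (0.61 log units; beyond the scatter), so this place, para to a large group, is sensitive to what sits on it. Among these compounds, the earlier compounds offered no step between close relatives, and this is the first sign that swapping one heavy atom for another here can move the number beyond the scatter. The result comes from a single pair, so it describes this swap on this one scaffold and is not a general rule.

On these data alone, whether a chlorine atom, a hydroxyl or an amine at the same place would read like the fluoro compound, like the methyl compound or like neither remains open. What lies behind the step is open too, and nothing measured here bears on it.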